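A Methylfuran Group Replaces the Hydroxynaphthyl Group

The compounds below may be only part of what the source reports. "The series", "measured", "known", "first", "only" and "open" are said of these compounds alone.

Compound 2 `N#CC1=C(N)N(c2ccc(S(N)(=O)=O)cc2)C2=C(CCCC2)C1c1c(O)ccc2ccccc12` carries a 2-hydroxynaphthalen-1-yl group on a saturated ring carbon of the shared core. Among the compounds with values here, in a functional assay on Ehrlich cells (Mus musculus) for cytotoxicity, read by trypan blue exclusion, with a stated time of 2 h, tested at 25 ug/mL (a lower number here means a weaker effect, a higher number a stronger effect of the compound at the concentration tested), compound 2 gives 5%, the lowest of the two numbers measured so far. Its nearest neighbour is compound 1 `N#CC1=C(N)N(c2ccc(S(N)(=O)=O)cc2)C2=C(CCCC2)C1c1ccc(Cl)c(Cl)c1`, which in this assay gives 40%; the exchange of 3,4-dichlorophenyl for 2-hydroxynaphthalen-1-yl on that carbon gave a number 35 percentage points lower from compound 1 to compound 2 (beyond the scatter).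

Compound 3 `Cc1ccc(C2C(C#N)=C(N)N(c3ccc(S(N)(=O)=O)cc3)C3=C2CCCC3)o1` has not yet been measured. It differs from compound 2 in one place: 5-methylfuran-2-yl in place of 2-hydroxynaphthalen-1-yl on a saturated ring carbon. Within the data shown here, the single measured step bears on this change, since it alters the same saturated ring carbon, and a number 35 percentage points lower from compound 1 to compound 2 (beyond the scatter) shows that the group on this carbon can shift the read-out by a large amount. Among the measured compounds shown here, no measured compound carries a 5-methylfuran-2-yl group, so the direction of the new step is uncertain. Compound 3 is expected to land between the two measured values, with a number 20 percentage points higher from compound 2 to compound 3 (beyond the scatter) expected as the step, and its estimate is 25%, expected to lie between 5% and 50%.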

Compound 3, a percentage reported as activity, at one concentration (the size of the read-out at that concentration, not a potency): 10%
Beside the measured number, compound 3's estimate is 15 percentage points above it; measured number inside the range.
By their numbers in this assay, from the lowest: compounds 2 and 3 (each within the scatter of the next); then compound 1.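

In this assay, 5-methylfuran-2-yl in place of 2-hydroxynaphthalen-1-yl gave a number 5 percentage points higher from compound 2 to compound 3 (within the scatter), so this read-out does not separate a group of one five-membered aromatic ring with 6 heavy atoms and 0 hydrogen-bond donors from one of two six-membered aromatic rings with 11 heavy atoms and 1 hydrogen-bond donor. The exchange of 3,4-dichlorophenyl for 5-methylfuran-2-yl gave a number 30 percentage points lower from compound 1 to compound 3 (beyond the scatter), which means that two quite different groups on this saturated ring carbon now stand well under compound 1, and among these three compounds only the 3,4-dichlorophenyl group sets itself apart. Nothing measured here accounts for this difference.

From the compounds shown here alone, it remains open whether the higher number of compound 1 goes with the two chlorine atoms or with the phenyl ring itself, a question that a plain phenyl or a 4-chlorophenyl group on this carbon would address. Also open, going by these compounds, is how an unsubstituted furan-2-yl, a 4-aminophenyl or a saturated cyclohexyl group would read here, and whether compound 2 and compound 3 would stay level at other concentrations or exposure times.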